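From compound 3 to compound 4: one ring group changes

The source may report more compounds than this note shows. Statements on the series, on what has been measured and on what is new or still open speak of the compounds shown alone.

- compound 1 `COc1ccccc1-n1nc([C@H]2C[C@@H](C)O[C@@H](C)C2)cc1-c1ccc(Cl)cc1` with 64%
- compound 2 `COc1ccccc1-n1nc(C2CC(C)(C)OC(C)(C)C2)cc1-c1ccc(Cl)cc1` with 97%
- compound 3 `COc1ccccc1-n1nc([C@@H]2CCO[C@@H](C(C)C)C2)cc1-c1ccc(Cl)cc1` with 26%

In an ADME assay on microsomes from liver (Homo sapiens) for metabolic stability, with a stated time of 10 min (a higher number here means that more of the compound is left, a lower number that less of the compound is left), compound 3 stands lowest of the three at 26% on the scale. The gap to the nearest value is large (a number 38 percentage points lower from compound 1 to compound 3 (beyond the scatter)). Compound 4 `COc1ccccc1-n1nc(C2=CC(C)(C)OC(C)(C)C2)cc1-c1ccc(Cl)cc1` swaps the ring group on an aromatic carbon and leaves the rest of the structure unchanged (a group of 10 heavy atoms (9 carbon, 1 oxygen; one six-membered non-aromatic ring with 1 hetero atom) in place of a group of 9 heavy atoms (8 carbon, 1 oxygen; one six-membered non-aromatic ring with 1 hetero atom), on an aromatic carbon). The entering group holds a double bond outside aromatic rings, and otherwise it matches the 2,2,6,6-tetramethyloxan-4-yl group of compound 2. That makes compound 2 the closest guide. The step between the groups of compound 2 and compound 3 is the largest measured so far (a number 71 percentage points lower from compound 2 to compound 3 (beyond the scatter)). The step from the 2,6-dimethyloxan-4-yl group to the 2,2,6,6-tetramethyloxan-4-yl group is also large and favours the same group (a number 33 percentage points higher from compound 1 to compound 2 (beyond the scatter)). Going by the values given here, no measured compound carries the double bond, so its influence is unknown and the range must stay wide. A large rise in this assay is expected (a number 59 percentage points higher from compound 3 to compound 4 (beyond the scatter)). Compound 4 is estimated at 85% with an expected range between 62% and 99% in this assay.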

Compound 4, percent of the compound remaining: 96%
Compound 4: middle estimate off by 11 percentage points, on the low side; the range from low to high includes it.
By their numbers in this assay, from the lowest: compound 3; then compound 1; then compounds 4 and 2 (each within the scatter of the next).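

In this assay, going by these compounds alone, the double bond outside aromatic rings in compound 4 leaves it indistinguishable from the fully saturated 2,2,6,6-tetramethyloxan-4-yl group of compound 2 (a number 1 percentage points lower from compound 2 to compound 4 (within the scatter)), which answers the one question the earlier compounds could not address. The new ring group also stands clearly apart from both less substituted groups, the 2-isopropyloxan-4-yl group (a number 70 percentage points higher from compound 3 to compound 4 (beyond the scatter)) and the 2,6-dimethyloxan-4-yl group (a number 32 percentage points higher from compound 1 to compound 4 (beyond the scatter)), so among these four compounds, the two rings with four methyl groups are the two that leave the most compound in this test, whether or not the ring holds the double bond. No supporting measurement is available to explain why these groups behave this way.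

Compound 2 at 97% and compound 4 at 96% both lie near the top of the scale, so any real difference between these two groups could be hidden there. As far as these compounds go, it also remains open whether a single pair of methyl groups, as in a 2,2-dimethyloxan-4-yl group, would be enough, and whether an amine nitrogen could take the place of the ring oxygen with the same outcome.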